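The compounds below may be only part of what the source reports. "The series", "measured", "known", "first", "only" and "open" are said of these compounds alone.

Measured compounds and their values:
compound 1, `COc1ccc(C2C(O)C(=O)N2c2cc(OC)c(OC)c(OC)c2)cc1` — 12 nM
compound 2, `CCSc1ccc(C2CC(=O)N2c2cc(OC)c(OC)c(OC)c2)cc1` — 311 nM
compound 3, `COc1ccc(C2C(C3CC3)C(=O)N2c2cc(OC)c(OC)c(OC)c2)cc1` — 107 nM

In a functional assay on HT-29 cells (Homo sapiens) for inhibition, read by sulforhodamine B assay, with a stated time of 72 h (a higher number here means a weaker inhibitor, a lower number a stronger inhibitor), compound 1 stands lowest of the three numbers. Its nearest neighbour is compound 3, reached by an 8.9-fold higher number from compound 1 to compound 3 (0.95 log units; beyond the scatter) with cyclopropyl in place of hydroxy on a saturated ring carbon. Within the data shown here, compound 2 lies furthest away, and since it differs from compound 1 in more than one place, its value says only that the number is higher there.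

Compound 4, `CCOc1ccc(C2C(O)C(=O)N2c2cc(OC)c(OC)c(OC)c2)cc1`, is the unmeasured member of the set. It differs from compound 1 by methyl in place of hydrogen on a saturated chain carbon bound to an oxygen on an aromatic ring. Among the measured compounds shown here, none of the measured steps touches this part of the molecule: the one single-place step available concerns the saturated ring carbon, not the chain carbon bound to the aromatic oxygen, so it offers no direct guide. The change is a single carbon added at the edge of the molecule, and in the absence of any comparable step the expectation is a small shift, if anything toward a higher number. The step expected is a 2.1-fold higher number from compound 1 to compound 4 (0.32 log units; beyond the scatter). Compound 4 is therefore estimated at 25 nM, with a range from 8 nM to 80 nM.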

Compound 4, half-maximal inhibitory concentration: 15 nM
For compound 4 the middle estimate is 1.7-fold (0.22 log units) above the measured one; low and high end bracket the measured number.
By their numbers in this assay, from the lowest: compounds 1 and 4 (each within the scatter of the next); then compound 3; then compound 2.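

In this assay, among these compounds, the one step at the saturated chain carbon bound to an oxygen on an aromatic ring, methoxy to ethoxy, is a 1.3-fold higher number from compound 1 to compound 4 (0.10 log units; within the scatter), so the two compounds cannot be told apart. Among the compounds shown here, this position therefore accepts the added methyl with no difference beyond the usual scatter, whereas the only earlier single-place step, cyclopropyl in place of hydroxy on a saturated ring carbon, was an 8.9-fold higher number from compound 1 to compound 3 (0.95 log units; beyond the scatter), a different change at a different place. Nothing at hand bears on why the methyl step reads as it does.

The compounds shown leave open whether this flat reading extends past ethoxy to a longer chain such as propyl or butyl, or to a chain ending in an amine or a carboxylic acid, since a single added methyl says nothing about how far the position can be taken. They also leave open whether ethoxy in place of methoxy would read the same on a core carrying cyclopropyl on the saturated ring carbon, as compound 3 does at 107 nM.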